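Switching an Ester for an Ethyl Amide on a Diene Chain

The source may report more compounds than this note shows. Statements on the series, on what has been measured and on what is new or still open speak of the compounds shown alone.

Of the compounds shown here, two have been measured so far. Compound 1, with the structure `COC(=O)/C=C(C)/C=C/CC(C)CCCC(C)(C)OC`, is one of them; compound 2, with the structure `C=CCNC(=O)/C=C(C)/C=C/CC(C)CCCC(C)C`, is the other. In a physicochemical assay for lipophilicity (on this read-out higher numbers stand for higher lipophilicity and lower numbers for lower lipophilicity), compound 1 gives 5, and in this assay compound 2 gives 5.23. Compound 1 thus has the lower of the two numbers, but the gap to compound 2 lies within the scatter of this kind of measurement, so the two cannot be told apart on lipophilicity.

The next compound, compound 3, has the structure `CCNC(=O)/C=C(C)/C=C/CC(C)CCCC(C)(C)OC`. It differs from compound 1 in one place: ethylamino in place of methoxy on a carbonyl carbon. Nothing in the measured pair reports the effect of this exact change, since compound 2 differs from compound 1 in two places at once. The expectation for this step is a modest fall in this assay, slightly beyond the scatter, that is, a step from compound 1 to compound 3 of a number 0.40 log units lower from compound 1 to compound 3 (beyond the scatter). Compound 3 is therefore expected to give about 4.6, with a plausible range from 4 to 5.2.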

Compound 3, partition coefficient: 4.04
Compound 3: middle estimate off by 0.56 log units, on the high side; low and high end bracket the measured number.
By their numbers in this assay, from the lowest: compound 3; then compounds 1 and 2 (each within the scatter of the next).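

Among the compounds shown here, on the carbonyl carbon, putting ethylamino in place of methoxy gives, in this assay, a number 0.96 log units lower from compound 1 to compound 3 (beyond the scatter) and is the first change that can be read on its own. The entering group is the larger one by count, with 3 heavy atoms against 2, and it carries 1 hydrogen-bond donor where methoxy carries none, so at this position a gain in heavy atoms does not come with a higher number. No independent measurement is available to explain the size or direction of this step.

The compounds shown leave open how the step divides between the amide hydrogen and the ethyl chain: dimethylamino on the same carbonyl carbon has no such hydrogen, while methylamino has a shorter chain, so the two would help to pull those parts apart. Also open, from the compounds shown here alone, is whether a similar step would appear with a different far end of the chain, since compound 2 differs from compound 1 in two places and cannot isolate that question.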